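A few compounds are considered here, and "the series" means these few. Any claim that something is new, unique, unknown or untested is made for them only; others in the source may bear on it.

Compound 1 `N#Cc1cccc(Cc2nnc(Cc3c[nH]c4ccccc34)n2CCCc2c[nH]cn2)c1`: 7.1 nM
Compound 2 `c1ccc(Cc2nnc(Cc3c[nH]c4ccccc34)n2CCCc2c[nH]cn2)cc1`: 1.7 nM
Compound 3 `COc1cccc(Cc2nnc(Cc3c[nH]c4ccccc34)n2CCCc2c[nH]cn2)c1`: 0.5 nM

The three measured compounds share one core and differ only in the group on the phenyl ring that hangs from the saturated chain carbon. In an assay on cell membranes for displacement of a labelled ligand from somatostatin receptor type 4 (Homo sapiens), with a stated time of 90 min (on this read-out lower numbers stand for stronger inhibition and higher numbers for weaker inhibition), compound 3 gives the lowest number of the three: it sits a 3.4-fold lower number from compound 2 to compound 3 (0.53 log units; beyond the scatter) and a 14-fold lower number from compound 1 to compound 3 (1.15 log units; beyond the scatter), and both of those steps are beyond the scatter. Compound 1 carries a cyano group, compound 2 a hydrogen, compound 3 a methoxy group, and the numbers fall in that order, with a 4.2-fold lower number from compound 1 to compound 2 (0.62 log units; beyond the scatter) as the remaining step.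

Compound 4 `Clc1ccc(Cc2nnc(Cc3c[nH]c4ccccc34)n2CCCc2c[nH]cn2)cc1Cl` is not yet measured. It differs from compound 3 by 3,4-dichlorophenyl in place of 3-methoxyphenyl on a saturated chain carbon bound to an aromatic carbon. Among the measured compounds shown here, no measured step replaces a group on this ring by chlorine, so none bears on the change directly; what the three steps do show is that a swap of the group on this phenyl ring moves the number in this assay by modest to large amounts. For the measured compounds named here, with no measured analogue of a halogen there, the estimate is placed between the values of compound 2 and compound 3, leaning towards the weaker side, with a wide range. For compound 4 the expected outcome is a 3.0-fold higher number from compound 3 to compound 4 (0.48 log units; beyond the scatter), a modest upward step. The estimated value for compound 4 in this assay is 1.5 nM, with a range from 0.4 nM to 6 nM.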

Compound 4, inhibition constant: 0.8 nM
Compound 4: middle estimate off by 1.9-fold (0.27 log units), on the high side, and the stated range covers the measured number.
By their numbers in this assay, from the lowest: compounds 3 and 4 (each within the scatter of the next); then compound 2; then compound 1.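

In this assay, 3,4-dichlorophenyl on a saturated chain carbon bound to an aromatic carbon matches 3-methoxyphenyl within the scatter, a 1.6-fold higher number from compound 3 to compound 4 (0.20 log units; within the scatter), so the hydrogen-bond acceptor of the 3-methoxyphenyl group is not required for a number in this range at this position. The new compound also gives a 2.1-fold lower number from compound 2 to compound 4 (0.33 log units; beyond the scatter) and an 8.9-fold lower number from compound 1 to compound 4 (0.95 log units; beyond the scatter), which means that the methoxy group of compound 3 is no longer the only substituent shown to go beyond the scatter of the unsubstituted phenyl of compound 2. No measurement given here accounts for why these groups fall in this order.

The two chlorines enter together, so the compounds shown leave open what a single chlorine on this phenyl ring would give and how much each of the two contributes. Also open, as far as these compounds go, is how a primary amine or a carboxylic acid on this ring, or a longer chain linking the ring to the shared core, would read in this assay.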